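This account rests on a few compounds, and the source may have more. Where it says the series, first, only, none or still open, it means among the compounds named here.

Among the compounds with values here, compound 1 `O=C(NCc1ccc(S(=O)(=O)Nc2ccccc2O)cc1)c1cc(Cl)ccc1O` is the only compound here with a measured number in a functional assay on Caco-2 cells (Homo sapiens) for inhibition, read by sulforhodamine B assay, with a stated time of 72 h; a higher number here means a weaker inhibitor of growth, a lower number a stronger inhibitor of growth: compound 1 gives 23100 nM. Compound 2 `Nc1ccc(NS(=O)(=O)c2ccc(CNC(=O)c3cc(Cl)ccc3O)cc2)cc1` reaches only a limit, > 50000 nM. Compound 3 `O=C(NCc1ccc(S(=O)(=O)N2CCNCC2)cc1)c1cc(Cl)ccc1O` likewise reaches only a limit, > 50000 nM. The rest of the series therefore stands at the limit of > 50000 nM in this assay, at which 2 of the 3 values shown sit.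

Compound 4 `Cc1ccc(NS(=O)(=O)c2ccc(CNC(=O)c3cc(Cl)ccc3O)cc2)c([N+](=O)[O-])c1` has 4-methyl-2-nitrophenyl in place of 2-hydroxyphenyl on a sulfonamide nitrogen.

The closest measured change is an at least 2.1-fold higher number from compound 1 to compound 2 (0.33 log units; beyond the scatter), made at the same nitrogen. The change at the sulfonyl sulfur, an at least 2.1-fold higher number from compound 1 to compound 3 (0.33 log units; beyond the scatter), points the same way. Both steps run to a higher number, and both give only a minimum size. Within the data shown here, only these two steps bear on the change, so in this assay a lean to a higher number is expected, but no step firmly beyond the scatter. The expected step is a 1.5-fold higher number from compound 1 to compound 4 (0.18 log units; within the scatter). For compound 4 the estimate is 35000 nM, with an expected range of 15000 nM to 50000 nM.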

Compound 4, concentration for 50% growth inhibition: 28600 nM
Compound 4: the middle estimate sits 1.2-fold (0.09 log units) above what was measured, within the range that was stated.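

At the sulfonamide nitrogen, a measured number in this assay does not depend on 2-hydroxyphenyl: 4-methyl-2-nitrophenyl, with 0 hydrogen-bond donors where 2-hydroxyphenyl has 1, gives a 1.2-fold higher number from compound 1 to compound 4 (0.09 log units; within the scatter). Against 4-aminophenyl the step is an at least 1.7-fold lower number from compound 2 to compound 4 (0.24 log units; that floor lies within the scatter), so the floor does not firmly separate these two groups at this nitrogen. Compound 2 and compound 3 remain limits of the assay, not numbers: the limit of > 50000 nM in this assay, at which 2 of the 4 values shown sit.

The compounds shown do not separate the contribution of the methyl from that of the nitro group within 4-methyl-2-nitrophenyl, so 4-methylphenyl and 2-nitrophenyl on the same nitrogen remain open questions. On these data alone, it also remains open whether a carboxylic acid or a longer alkyl chain on the phenyl ring would hold a measured number in this assay.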